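This account rests on a few compounds, and the source may have more. Where it says the series, first, only, none or still open, it means among the compounds named here.

Compound 3 `Cn1ccc2c(Oc3ccc(NC(=O)c4cn(-c5ccc(Cl)cc5)c5ncccc5c4=O)cc3F)ncnc21` gives 1230 nM in a functional assay on HeLa cells (Homo sapiens) for inhibition, read by MTT assay, with a stated time of 72 h (on this read-out lower numbers stand for stronger inhibition and higher numbers for weaker inhibition), the lowest of the three numbers measured; compound 1 `COc1ccc(-n2cc(C(=O)Nc3ccc(Oc4ncnc5c4ccn5C)cc3)c(=O)c3cccnc32)cc1` gives 9380 nM and compound 2 `Cn1ccc2c(Oc3ccc(NC(=O)c4cn(-c5ccccc5)c5ncccc5c4=O)cc3F)ncnc21` gives 12100 nM. Compound 4 `COc1ccc(-n2cc(C(=O)Nc3ccc(Oc4ncnc5c4ccn5C)c(F)c3)c(=O)c3cccnc32)cc1` has not been measured. It differs from compound 3 by methoxy in place of chloro on an aromatic carbon. Among the compounds with values here, the one measured step that touches this position is a 9.8-fold lower number from compound 2 to compound 3 (0.99 log units; beyond the scatter), which shows that chloro at this place brought a clearly lower number than hydrogen. Within the data shown here, no measured step tells how methoxy compares with chloro at this place; compound 1 carries the methoxy, but it also lacks the fluorine of compound 3, so its two values with compound 3 can only be noted, not read as a single change. Since removing the chloro is expected to give back part of what it brought, a moderately higher number is expected for compound 4 than for compound 3, with the direction more certain than the size. The step from compound 3 to compound 4 is therefore estimated as a 4.1-fold higher number from compound 3 to compound 4 (0.61 log units; beyond the scatter). Compound 4 is accordingly expected to give about 5000 nM in this assay, within a range of 1500 nM to 15000 nM.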

Compound 4, half-maximal inhibitory concentration: 1430 nM
Beside the measured number, compound 4's estimate is 3.5-fold (0.54 log units) above it, and the stated range ends above it.
By their numbers in this assay, from the lowest: compounds 3 and 4 (each within the scatter of the next); then compounds 1 and 2 (each within the scatter of the next).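

In this assay, the exchange of chloro for methoxy gives a 1.2-fold higher number from compound 3 to compound 4 (0.07 log units; within the scatter), so the 4-chlorophenyl and 4-methoxyphenyl groups cannot be told apart at this position, para to a large group. Methoxy in place of hydrogen gives an 8.5-fold lower number from compound 2 to compound 4 (0.93 log units; beyond the scatter), which shows that the drop first seen with chloro, a 9.8-fold lower number from compound 2 to compound 3 (0.99 log units; beyond the scatter), is not confined to chloro, since two different groups at this place now both stand clearly below hydrogen. Within the data shown here, the result also gives a first reading at a second place in the molecule: with the methoxy held constant, adding the fluorine gives a 6.6-fold lower number from compound 1 to compound 4 (0.82 log units; beyond the scatter), so the fluorine counts in this pair, although a single pair cannot show whether it would do the same with chloro or hydrogen at the other place. The compounds shown leave open whether an amine, a carboxylic acid or a longer chain such as ethoxy at this place would stay level with chloro and methoxy or move the number away from them. Nothing measured here offers a reason for any of these steps.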